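The source may report more compounds than this note shows. Statements on the series, on what has been measured and on what is new or still open speak of the compounds shown alone.

Compound 1 `CC1CC(C)CN(c2nc(Nc3ccc(C#N)c(C(F)(F)F)c3)nc(Oc3ccnc4ccccc34)n2)C1` gives 27200 nM
Compound 2 `CN1CCN(c2nc(Nc3ccc(C#N)c(C(F)(F)F)c3)nc(Oc3ccnc4ccccc34)n2)CC1` gives 51200 nM

Both numbers come from a functional assay on DU-145 cells (Homo sapiens) for cytotoxicity, read by sulforhodamine B assay, with a stated time of 48 h (a lower number here means a stronger inhibitor of growth, a higher number a weaker inhibitor of growth), and they sit close together. Among the compounds with values here, the one measured step is a 1.9-fold higher number from compound 1 to compound 2 (0.27 log units; within the scatter) so compound 2 stands level with compound 1 within the usual scatter. Compound 3 `COc1ccc(CN2CCN(c3nc(Nc4ccc(C#N)c(C(F)(F)F)c4)nc(Oc4ccnc5ccccc45)n3)CC2)c(OC)c1OC` alters compound 2 at a different place. The change is 2,3,4-trimethoxyphenyl in place of hydrogen on a saturated chain carbon bound to an amine nitrogen in a ring and it falls on a saturated chain carbon bound to an amine nitrogen in a ring. Within the data shown here, the measured step exchanged a group on an aromatic carbon instead, so it bears only loosely on this change, and no measured compound carries the new group. No step beyond the scatter is therefore expected in this assay and no direction is firmly supported. The estimated step is a 1.7-fold lower number from compound 2 to compound 3 (0.23 log units; within the scatter) as a best guess. For compound 3 the expected value is 30000 nM with an estimated range from 10000 nM to 80000 nM as a deliberately wide band.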

Compound 3, concentration for 50% growth inhibition: > 100000 nM
Compound 3 ended at the assay's limit; the forecaster's own chance of this, stated with the estimate: 15%; middle value at least 3.3-fold (0.52 log units) from the limit.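

Placing 2,3,4-trimethoxyphenyl on a saturated chain carbon bound to an amine nitrogen in a ring gives an at least 1.9-fold higher number from compound 2 to compound 3 (0.29 log units; that floor lies within the scatter) in this assay, the first measured change at this place. Compound 3 reads > 100000 nM, which is a limit of the assay and not a number. This change therefore brought no stronger inhibition of growth, though the true size of the step stays unknown because the reading stops at a ceiling: the limit of > 100000 nM in this assay, at which 1 of the 3 values shown sits.

The compounds shown do not separate the ring itself from its three methoxy groups, so a plain phenyl at this place could read differently. From the compounds shown here alone, whether a smaller addition such as a hydroxyl or an amine would give a lower number in this assay also stays open.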